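Amide cap change on the piperidine series: isopentyl to tolyl

A few compounds are considered here, and "the series" means these few. Any claim that something is new, unique, unknown or untested is made for them only; others in the source may bear on it.

Measured so far:
compound 1 `CC(C)CCC(=O)N[C@@H](C(=O)N1CCC(c2ccc(Cl)cc2)CC1)C(C)C` 26 nM
compound 2 `CC(C)C(NS(=O)(=O)Cc1ccccc1)C(=O)N1CCC(c2ccc(Cl)cc2)CC1` 303 nM

In an assay on THP-1 cells for displacement of a labelled ligand from C-C chemokine receptor type 1 (Homo sapiens) (on this read-out higher numbers stand for weaker inhibition and lower numbers for stronger inhibition), compound 1 gives 26 nM, the lower of the two numbers; compound 2 gives 303 nM, a higher number beyond the scatter. Compound 3 `Cc1ccccc1C(=O)N[C@@H](C(=O)N1CCC(c2ccc(Cl)cc2)CC1)C(C)C` is not yet measured. It differs from compound 1 by 2-methylphenyl in place of isopentyl on a carbonyl carbon. Going by the values given here, no measured pair in this assay isolates such a change, so the expected step of a 1.9-fold higher number from compound 1 to compound 3 (0.28 log units; within the scatter) is taken as small, in the direction of a somewhat higher number but not clearly beyond the scatter. For compound 3 the estimate in this assay is 50 nM, with a range from 10 nM to 250 nM.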

Compound 3, half-maximal inhibitory concentration: 32 nM
Compound 3: middle estimate off by 1.6-fold (0.19 log units), on the high side; measured number inside the range.
By their numbers in this assay, from the lowest: compounds 1 and 3 (each within the scatter of the next); then compound 2.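

In this assay, 2-methylphenyl in place of isopentyl on a carbonyl carbon gives a 1.2-fold higher number from compound 1 to compound 3 (0.09 log units; within the scatter). This position therefore accepts an aromatic ring of carbon only as well as a branched open chain, with no difference between compound 1 and compound 3 that can be read. Nothing measured on these compounds offers an explanation for this result.

Open, as far as these compounds go, is whether the methyl on the ring matters, since plain phenyl has no reading here. Also open, from the compounds shown here alone, is how a longer chain, an amine or a carboxylic acid on this carbonyl would read.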